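This account rests on a few compounds, and the source may have more. Where it says the series, first, only, none or still open, it means among the compounds named here.

The measured compounds are: compound 1, `COc1cccc(-n2cc(CO/N=C3\CC[C@]4(C)[C@@H](CC/C=C(\C)CC/C=C(\C)CCC=C(C)C)[C@](C)(O)CC[C@H]4C3(C)C)nn2)c1`, which in a functional assay on DU-145 cells (Homo sapiens) for cytotoxicity, read by MTT assay, with a stated time of 48 h (on this read-out lower numbers stand for stronger inhibition and higher numbers for weaker inhibition), gives 30500 nM; compound 2, `CC(C)=CCC/C(C)=C/CC/C(C)=C/CC[C@@H]1[C@@]2(C)CC/C(=N\OCc3cn(-c4ccc(Cl)cc4)nn3)C(C)(C)[C@@H]2CC[C@@]1(C)O`, which in this assay gives 16200 nM; and compound 3, `CC(C)=CCC/C(C)=C/CC/C(C)=C/CC[C@@H]1[C@@]2(C)CC/C(=N\OCc3cn(-c4ccccc4C#N)nn3)C(C)(C)[C@@H]2CC[C@@]1(C)O`, which in this assay gives 25100 nM.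

Compound 3 stands second highest of the three numbers. Its nearest neighbour is compound 1, with a 1.2-fold lower number from compound 1 to compound 3 (0.08 log units; within the scatter), and its furthest is compound 2, with a 1.5-fold higher number from compound 2 to compound 3 (0.19 log units; within the scatter); both of these steps fall within the scatter. Compound 4, `CC(C)=CCC/C(C)=C/CC/C(C)=C/CC[C@@H]1[C@@]2(C)CC/C(=N\OCc3cn(-c4cccc(O)c4)nn3)C(C)(C)[C@@H]2CC[C@@]1(C)O`, has not yet been measured. It differs from compound 3 in one place: 3-hydroxyphenyl in place of 2-cyanophenyl on an aromatic nitrogen.

All three measured steps bear on this change, since each of them also exchanges the group on the same aromatic nitrogen for another: a 1.9-fold lower number from compound 1 to compound 2 (0.27 log units; within the scatter), a 1.2-fold lower number from compound 1 to compound 3 (0.08 log units; within the scatter) and a 1.5-fold higher number from compound 2 to compound 3 (0.19 log units; within the scatter). None of them moves the number beyond the scatter, so the group on that nitrogen has so far made no difference that can be read from these data. On that basis no step beyond the scatter is expected in this assay for 3-hydroxyphenyl in place of 2-cyanophenyl either. The expected step is a 1.0-fold lower number from compound 3 to compound 4 (0.00 log units; within the scatter). Compound 4 is therefore estimated at 25000 nM, with a range from 10000 nM to 60000 nM.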

Compound 4, half-maximal inhibitory concentration: 17500 nM
For compound 4 the middle estimate is 1.4-fold (0.15 log units) above the measured one; the measured number falls inside the stated range.
By their numbers in this assay, from the lowest: compounds 2, 4, 3 and 1 (each within the scatter of the next).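

In this assay, going by these compounds alone, 3-hydroxyphenyl is the first group on this aromatic nitrogen to carry a hydrogen-bond donor, yet its exchange for 2-cyanophenyl gives a 1.4-fold lower number from compound 3 to compound 4 (0.16 log units; within the scatter), so bringing in a donor here produces no step that stands out from the scatter. The narrowest change so far, hydrogen in place of methyl on the oxygen on the aromatic ring, gives a 1.7-fold lower number from compound 1 to compound 4 (0.24 log units; within the scatter), and the exchange for 4-chlorophenyl gives a 1.1-fold higher number from compound 2 to compound 4 (0.03 log units; within the scatter), which extends the flat picture across all four aryl groups shown, with no compound among them going against it. No measurement at hand offers an explanation for this lack of response.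

Every group shown on this nitrogen is a substituted phenyl, so it remains open whether a benzyl group, a pyridine ring, or a phenyl ring bearing an amine or a carboxylic acid would move the number beyond the scatter. On these data alone, it is also open whether any change to the shared core, rather than to this group, would do so.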